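The source may report more compounds than this note shows. Statements on the series, on what has been measured and on what is new or still open speak of the compounds shown alone.

Measured so far in a functional assay on MCF7 cells (Homo sapiens) for inhibition, read by MTT assay, with a stated time of 24 h; on this read-out higher numbers stand for weaker inhibition and lower numbers for stronger inhibition:
compound 1 `CCOC(=O)C1=Cc2ccccc2OC1(OCc1cn(CC(=O)Nc2ccc(C)cc2)nn1)C(F)(F)F`: > 150000 nM
compound 2 `CCOC(=O)C1=Cc2ccccc2OC1(OCc1cc(-c2ccc(OC)cc2)no1)C(F)(F)F`: > 150000 nM

Compound 1 stands where every value shown stands: its figure in this assay, > 150000 nM, is a limit of the assay and not a number. Compound 2 likewise returns only a limit, > 150000 nM. For the measured compounds named here, both entries sit on (the limit of > 150000 nM in this assay, at which 2 of the 2 values shown sit), so no numerical spread exists among the measured compounds and no step between them has been worked out; the two values show only that neither reaches measurable inhibition.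

Compound 3 `CCOC(=O)C1=Cc2ccccc2OC1(OCc1cn(-c2ccc([N+](=O)[O-])cc2)nn1)C(F)(F)F` is not yet measured. It differs from compound 1 by 4-nitrophenyl in place of ((4-methylphenyl)carbamoyl)methyl on an aromatic nitrogen. Going by the values given here, no measured step shows what a change on this aromatic nitrogen does in this assay. The step expected is a step that the limit leaves unreadable from compound 1 to compound 3, none beyond the scatter, because compound 1 itself stands at the limit of > 150000 nM in this assay, at which 2 of the 2 values shown sit. Compound 3 is expected to give about 200000 nM, within 80000 nM to 600000 nM, most likely again reported only as a limit.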

Compound 3, half-maximal inhibitory concentration: > 150000 nM
Compound 3: a limit, no number; the forecaster's own chance of this, stated with the estimate: 75%; the middle value lies beyond the limit too.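

In this assay, for the compounds shown here, compound 1 and compound 3 each return only a limit of the assay and not a number, so no step between them can be read. The compounds shown leave open whether in this assay any change on the shared core gives measurable inhibition.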